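The compounds below may be only part of what the source reports. "The series", "measured", "known", "first", "only" and "open" are said of these compounds alone.

In a functional assay on MCF7 cells (Homo sapiens) for antiproliferative activity, read by CellTiter-Glo, with a stated time of 5 days (a lower number here means a stronger inhibitor, a higher number a weaker inhibitor), compound 3 `O=C(O)/C=C/c1ccc(/C(=C(\c2ccccc2)C2CCC2)c2ccc(-c3cn[nH]c3)cc2)cc1` gives 11 nM, within the scatter of compound 1 `N#Cc1ccc(/C(=C(\c2ccc(/C=C/C(=O)O)cc2)c2ccc3nccn3c2)C2CCC2)c(Cl)c1` at 15 nM, while compound 2 `N#Cc1ccc(/C(=C(\c2ccc(/C=C/C(=O)O)cc2)c2ccc(-c3cncs3)cc2)C2CCC2)c(Cl)c1` gives the lowest number, 2.9 nM. The change to compound 4 `N#Cc1ccc(/C(=C(\c2ccc(/C=C/C(=O)O)cc2)c2ccc(-c3cn[nH]c3)cc2)C2CCC2)c(Cl)c1` is 2-chloro-4-cyanophenyl in place of phenyl on a double-bonded chain carbon bound to a double-bonded chain carbon and a saturated ring carbon. Within the data shown here, no measured step tests this swap directly. Among the measured compounds shown here, compounds 1 and 2 both carry the entering group, and the one measured step, a 5.2-fold lower number from compound 1 to compound 2 (0.71 log units; beyond the scatter), concerns a different group, so the entering group alone does not fix the number. Compound 2 at 2.9 nM is the closer guide, since it shares the entering group and has a phenyl-borne five-membered aromatic ring. A lower number is expected in this assay, an estimated 3.1-fold lower number from compound 3 to compound 4 (0.50 log units; beyond the scatter). For compound 4 the estimated value is 3.5 nM, with an expected range of 1.2 nM to 10 nM.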

Compound 4, half-maximal inhibitory concentration: 2.2 nM
The estimate for compound 4 lay 1.6-fold (0.20 log units) above the measured number; the range from low to high includes it.
By their numbers in this assay, from the lowest: compounds 4 and 2 (each within the scatter of the next); then compounds 3 and 1 (each within the scatter of the next).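

In this assay, among these compounds, 2-chloro-4-cyanophenyl in place of phenyl gives a 5.0-fold lower number from compound 3 to compound 4 (0.70 log units; beyond the scatter) with the rest of the structure held, the first direct reading of this group at this place. With that group present, 1H-pyrazol-4-yl in place of 1,3-thiazol-5-yl on an aromatic carbon gives a 1.3-fold lower number from compound 2 to compound 4 (0.12 log units; within the scatter) and a change of the whole group on the double-bonded chain carbon gives a 6.8-fold lower number from compound 1 to compound 4 (0.83 log units; beyond the scatter) for the second comparison. No measurement here gives a reason for these steps. Whether the chlorine or the nitrile accounts for the step from phenyl stays open. So does how a phenyl carrying only a methoxy group or an amine would read at this place.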